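One More Fluorine on the Lowest Number So Far

This account rests on a few compounds, and the source may have more. Where it says the series, first, only, none or still open, it means among the compounds named here.

In a functional assay on a cell-free system (Platelet, plasma, Homo sapiens) for inhibition (on this read-out lower numbers stand for stronger inhibition and higher numbers for weaker inhibition), compound 1 (`COc1ccc(NC(=O)C2CCCNC2)cc1`) gives 983000 nM and compound 2 (`N=C(N)N1CCCC(C(=O)Nc2cccc(OCc3ccc(-c4ccccc4)cc3)c2)C1`) gives 1000000 nM while compound 3 (`O=C(Nc1cccc(OCc2ccc(-c3ccc(F)cc3)cc2)c1)C1CCNCC1`) gives 35000 nM as the lowest number of the three, a gap beyond the scatter from each of the others. Compound 4 (`O=C(Nc1cccc(OCc2ccc(-c3cc(F)cc(F)c3)cc2)c1)C1CCNCC1`) carries 3,5-difluorophenyl in place of 4-fluorophenyl on an aromatic carbon. For the measured compounds named here, no two measured compounds differ in one place only, so the data do not show what a change of this kind does. The expected step of a 1.2-fold lower number from compound 3 to compound 4 (0.07 log units; within the scatter) is small, within the scatter and without a clear direction. For compound 4 the estimated value is 30000 nM with an expected range from 11000 nM to 90000 nM in this assay's units.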

Compound 4, half-maximal inhibitory concentration: 27800 nM
Compound 4: the middle estimate sits 1.1-fold (0.03 log units) above what was measured; measured number inside the range.
By their numbers in this assay, from the lowest: compounds 4 and 3 (each within the scatter of the next); then compounds 1 and 2 (each within the scatter of the next).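

Replacing 4-fluorophenyl with 3,5-difluorophenyl gives a 1.3-fold lower number from compound 3 to compound 4 (0.10 log units; within the scatter) in this assay. For the compounds shown here, this is the first comparison here between compounds that differ in one place, and it shows that adding a second fluorine and moving the fluorines on this ring leaves no change that can be told from the scatter. Nothing on hand explains why the two groups read alike. The compounds shown leave open whether an amine or a carboxylic acid on this ring would shift the number beyond the scatter.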